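Removing the Methoxy Group from Compound 3

A few compounds are considered here, and "the series" means these few. Any claim that something is new, unique, unknown or untested is made for them only; others in the source may bear on it.

Three measured compounds share one core and differ only at a single aromatic carbon. In a functional assay on HEp-2 cells (Homo sapiens) for cytotoxicity, read by MTT assay (on this read-out lower numbers stand for stronger inhibition and higher numbers for weaker inhibition), compound 1 `CC1=NNC(=O)C1C(c1c(-c2ccccc2)[nH]c2ccc(C)cc12)c1c(-c2ccccc2)[nH]c2ccc(Cl)cc12` gives 32400 nM and compound 2 `CC1=NNC(=O)C1C(c1c(-c2ccccc2)[nH]c2ccc(Cl)cc12)c1c(-c2ccccc2)[nH]c2ccc(Cl)cc12` gives 14600 nM. Compound 3 `COc1ccc2[nH]c(-c3ccccc3)c(C(c3c(-c4ccccc4)[nH]c4ccc(Cl)cc34)C3C(=O)NN=C3C)c2c1` gives 6200 nM, the lowest of the three numbers; the differences were a 5.2-fold lower number from compound 1 to compound 3 (0.72 log units; beyond the scatter) and a 2.4-fold lower number from compound 2 to compound 3 (0.37 log units; beyond the scatter), both beyond the usual scatter.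

Compound 4 `CC1=NNC(=O)C1C(c1c(-c2ccccc2)[nH]c2ccccc12)c1c(-c2ccccc2)[nH]c2ccc(Cl)cc12` differs from compound 3 in one place: hydrogen in place of methoxy on an aromatic carbon. Among the measured compounds shown here, the steps that bear on this are the two in which methoxy entered, a 5.2-fold lower number from compound 1 to compound 3 (0.72 log units; beyond the scatter) and a 2.4-fold lower number from compound 2 to compound 3 (0.37 log units; beyond the scatter), each lowering the number. For the measured compounds named here, no measured compound carries hydrogen at that place, so the size is uncertain, but taking methoxy away is expected to push the number back up modestly. Compound 4 is expected to give about 15000 nM, within 5000 nM to 45000 nM, an expected step of a 2.4-fold higher number from compound 3 to compound 4 (0.38 log units; beyond the scatter).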

Compound 4, half-maximal inhibitory concentration: 41700 nM
Compound 4: middle estimate off by 2.8-fold (0.44 log units), on the low side; the range from low to high includes it.
By their numbers in this assay, from the lowest: compound 3; then compound 2; then compounds 1 and 4 (each within the scatter of the next).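

With hydrogen now as a baseline, methoxy stands out at this aromatic carbon (a 6.7-fold higher number from compound 3 to compound 4 (0.83 log units; beyond the scatter)). Chloro also differs from hydrogen (a 2.9-fold higher number from compound 2 to compound 4 (0.46 log units; beyond the scatter)), whereas methyl cannot be separated from it (a 1.3-fold higher number from compound 1 to compound 4 (0.11 log units; within the scatter)). Nothing available explains why these groups differ. Still open, going by these compounds, is whether an ethoxy group, a hydroxyl group or an amine at this carbon would bring the number below that of compound 3. Also open, on these data alone, is whether the same order of groups would hold if the chloro that all four compounds share were replaced.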